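A few compounds are considered here, and "the series" means these few. Any claim that something is new, unique, unknown or untested is made for them only; others in the source may bear on it.

In a functional assay on HepG2 cells (Homo sapiens) for inhibition, read by MTT assay, with a stated time of 48 h (on this read-out lower numbers stand for stronger inhibition and higher numbers for weaker inhibition), compound 1 (`COc1ccc(N(C)c2nc(C)nc3ccccc23)cc1C(=O)OCC[Se]C#N`) gives 890 nM and compound 2 (`Cc1nc(N(C)c2ccc(OCC[Se]C#N)cc2)c2ccccc2n1`) gives 1680 nM with the two lying within the scatter of each other. Compound 3 (`Cc1nc(N(C)c2ccc([Se]C#N)c(Cl)c2)c2ccccc2n1`) gives 12 nM on the same read-out, a much lower number than that of compound 1 and beyond the scatter. Compound 1 therefore stands with compound 2 at the upper end of the three numbers, well away from compound 3.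

Compound 4 (`COc1ccc(N(C)c2nc(C)nc3ccccc23)cc1[Se]C#N`) has not yet been measured. Its change from compound 1 is a group of 3 heavy atoms (1 carbon, 1 nitrogen, 1 selenium; no ring) in place of a group of 8 heavy atoms (4 carbon, 1 nitrogen, 2 oxygen, 1 selenium; no ring), on an aromatic carbon at a place ortho to a methoxy group and meta to a large group. Compound 3 carries the same entering group on an aromatic carbon, whereas in compound 1 and compound 2 the selenium is not attached to an aromatic carbon. Three compounds are thin support for any pattern, and compound 3 also differs from compound 4 in its other ring substituents. Even so, compound 4 is expected to move toward compound 3 with its 12 nM and away from compound 1 with its 890 nM on this contrast. The expected step is a 25-fold lower number from compound 1 to compound 4 (1.41 log units; beyond the scatter) with the number falling beyond the scatter. For compound 4 the estimated value in this assay is 35 nM (expected range 8 nM to 200 nM).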

Compound 4, half-maximal inhibitory concentration: 59 nM
The estimate for compound 4 lay 1.7-fold (0.23 log units) below the measured number; measured number inside the range.
By their numbers in this assay, from the lowest: compound 3; then compound 4; then compounds 1 and 2 (each within the scatter of the next).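

In this assay, among the compounds shown here, placing the group of 3 heavy atoms in the position of the group of 8 heavy atoms, on an aromatic carbon ortho to a methoxy group and meta to a large group, gives a 15-fold lower number from compound 1 to compound 4 (1.18 log units; beyond the scatter) as the first step that can be read at one place, with the rest of the structure unchanged. This position is therefore not indifferent to the group it carries: the read-out shifts beyond the scatter when the selenium moves from a chain onto the aromatic carbon itself. No measurement of any property accompanies this step, and no cause can be assigned to it.

For the compounds shown here, the single pair changes chain length, the carbonyl and the attachment of selenium together, so it cannot show which of these carries the step, and a two-carbon chain joined directly to the aromatic carbon would be needed to separate them. Also open, as far as these compounds go, is whether selenium itself matters at this position, a question that a thiocyanate, a plain nitrile or a carboxylic acid on the same aromatic carbon would address.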